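Swapping thiomorpholine for morpholine on a thiosemicarbazone

This account rests on a few compounds, and the source may have more. Where it says the series, first, only, none or still open, it means among the compounds named here.

Of the compounds shown here, two have been tested so far. Compound 1, `N/C(=N\NC(=S)N1CCOCC1)c1ccccn1`, gives 87.2% in a functional assay on HeLa cells (Homo sapiens) for cytotoxicity, read by MTT assay, with a stated time of 72 h, tested at 100 uM; on this read-out lower numbers stand for less inhibition of growth and higher numbers for more inhibition of growth at the one concentration tested. Compound 2, `Cc1cccc(/C(N)=N/NC(=S)N2CCSCC2)n1`, gives 81.6% in this assay; this is the lower of the two numbers, but the gap to compound 1 is within the scatter, so the two are best read as alike. Compound 3, `Cc1cccc(/C(N)=N/NC(=S)N2CCOCC2)n1`, has not yet been measured. It differs from compound 2 in one place: morpholin-4-yl in place of thiomorpholin-4-yl on a thiocarbonyl carbon. Both measured compounds, each carrying one of these two rings, sit near the top of the scale at the single concentration used, so nothing here points to a shift beyond the scatter in either direction. The step from compound 2 to compound 3 is therefore expected to be a number 2.4 percentage points higher from compound 2 to compound 3 (within the scatter). For compound 3 the estimate in this assay is 84%, with a likely range from 70% to 95%.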

Compound 3, percent growth inhibition at one concentration: 82.4%
Compound 3: middle estimate off by 1.6 percentage points, on the high side, and the stated range covers the measured number.
By their numbers in this assay, from the lowest: compounds 2, 3 and 1 (each within the scatter of the next).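

With the core of compound 2 held constant, replacing thiomorpholin-4-yl with morpholin-4-yl on the thiocarbonyl carbon gives a number 0.8 percentage points higher from compound 2 to compound 3 (within the scatter) in this assay, a direct comparison showing that these two rings read as alike here. Compound 3 also isolates the other difference, with morpholin-4-yl held constant: methyl in place of hydrogen on an aromatic carbon gives a number 4.8 percentage points lower from compound 1 to compound 3 (within the scatter), so this change also leaves the compounds alike. No separate measurement is available to explain either result.

As far as these compounds go, it remains open whether a dimethylamino group or a longer carbon chain on the thiocarbonyl carbon would also give a similar number. With only one concentration tested, it is also unclear whether these compounds would remain alike at lower concentrations.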